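The compounds below may be only part of what the source reports. "The series", "measured", "known", "first", "only" and "open" are said of these compounds alone.

Working notes on the series in a functional assay on M14 cells (Homo sapiens) for cytotoxicity, read by resazurin assay, with a stated time of 72 h; a lower number here means a stronger inhibitor, a higher number a weaker inhibitor.

Compound 1 `O=C(/C=C/c1ccc(O)c(O)c1)OCc1c(-c2ccccc2)no[n+]1[O-]` gives 12500 nM. Compound 2 `COc1cc(/C=C/C(=O)OCc2c(-c3ccccc3)no[n+]2[O-])ccc1O` differs from compound 1 by methyl in place of hydrogen on an oxygen on an aromatic ring; in this assay compound 2 gives 14000 nM, so the measured step is a 1.1-fold higher number from compound 1 to compound 2 (0.05 log units; within the scatter).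

Compound 3 `O=C(/C=C/c1ccc(OCCCCCCO[N+](=O)[O-])c(O)c1)OCCCCCCO[N+](=O)[O-]` carries a different core; the difference between the two cores and that of compound 1 is not broken down here. In this assay compound 3 gives only a limit, > 50000 nM, which is the limit of > 50000 nM in this assay, at which 1 of the 3 values shown sits, and not a number.

Compound 4 `COc1cc(/C=C/C(=O)OCCCCCCO[N+](=O)[O-])ccc1OCCCCCCO[N+](=O)[O-]`, not yet measured in this assay, differs from compound 3 by methyl in place of hydrogen on an oxygen on an aromatic ring, the same change as from compound 1 to compound 2, made at the same kind of place on the aromatic ring oxygen. This change occurs twice among the compounds shown.

For the measured compounds named here, the step that the limit leaves unreadable from compound 3 to compound 4 is expected to be small, since the one measured instance of the change gave a 1.1-fold higher number from compound 1 to compound 2 (0.05 log units; within the scatter). Given that compound 3 already sits at the limit, compound 4 is expected to remain there too, near 70000 nM, with a range of 35000 nM to 150000 nM, and the assay will most likely again report only a limit.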

Compound 4, half-maximal inhibitory concentration: > 50000 nM
Compound 4 was reported as a limit; the forecaster's own chance of this, stated with the estimate: 80%; the middle value does not contradict the limit.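

No step can be read between compound 3 and compound 4, because both are reported only as limits and not as numbers: the limit of > 50000 nM in this assay, at which 2 of the 4 values shown sit.

The compounds shown leave open whether the change from hydroxy to methoxy has any measurable size on the core of compound 3, as the only readable instance of it comes from compound 1 and compound 2.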